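Swapping an Aryl Group on a Piperazine Nitrogen

The source may report more compounds than this note shows. Statements on the series, on what has been measured and on what is new or still open speak of the compounds shown alone.

Of the compounds shown here, three sharing one core have been measured in a functional assay on SK-N-SH cells (Homo sapiens) for inhibition, read by MTT assay; a higher number here means a weaker inhibitor, a lower number a stronger inhibitor. Compound 1 `CCCCCCCCn1cc(/C=C/C(=O)c2ccc(NC(=O)CN3CCN(c4ccccc4F)CC3)cc2)nn1` gives 60300 nM, compound 2 `O=C(CN1CCC(Cc2ccccc2)CC1)Nc1ccc(C(=O)/C=C/c2cn(Cc3ccc(Br)cc3)nn2)cc1` gives 42900 nM, and compound 3 `COc1ccccc1N1CCN(CC(=O)Nc2ccc(C(=O)/C=C/c3cn(Cc4ccc(Br)cc4)nn3)cc2)CC1` gives 28000 nM. Compound 3 has the lowest of the three numbers, yet compound 2 lies within the usual scatter of it, so only compound 1 stands clearly apart. Compound 4 `O=C(CN1CCN(c2ccc([N+](=O)[O-])cc2)CC1)Nc1ccc(C(=O)/C=C/c2cn(Cc3ccc(Br)cc3)nn2)cc1` is compound 3 with one change: 4-nitrophenyl in place of 2-methoxyphenyl on an amine nitrogen in a ring, a 4-nitrophenyl in place of a 2-methoxyphenyl on an amine nitrogen in a ring. Among the measured compounds shown here, no measured pair shows this kind of swap, so the size of its effect in this assay cannot be read from the data; a step no larger than the scatter is expected, a 1.1-fold higher number from compound 3 to compound 4 (0.03 log units; within the scatter). Compound 4 is therefore estimated at 30000 nM, between 12000 nM and 75000 nM.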

Compound 4, half-maximal inhibitory concentration: 26500 nM
Compound 4: middle estimate off by 1.1-fold (0.05 log units), on the high side, and the stated range covers the measured number.
By their numbers in this assay, from the lowest: compounds 4, 3, 2 and 1 (each within the scatter of the next, the first and the last beyond it).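

Among the compounds shown here, this is the first measured pair at this position. In this assay, 4-nitrophenyl in place of 2-methoxyphenyl on an amine nitrogen in a ring gives a 1.1-fold lower number from compound 3 to compound 4 (0.02 log units; within the scatter), so the two compounds read alike even though the group on the aromatic ring and its place on that ring both differ. No measurement at hand offers a reason for this result.

Still open, on these data alone, is whether the aromatic ring on this nitrogen matters at all. A methyl or an acetyl group in its place would test that.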